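Methylsulfanyl for methyl on the shared core: compound 4

A few compounds are considered here, and "the series" means these few. Any claim that something is new, unique, unknown or untested is made for them only; others in the source may bear on it.

Compound 1 `O=c1c2ccoc2ccn1[C@@H]1O[C@H](COP(=O)(O)OP(=O)(O)OP(=O)(O)O)[C@@H](O)[C@H]1O` gives 68 nM in a functional assay for agonist activity at P2Y purinoceptor 2 (Homo sapiens), read by FLIPR; on this read-out lower numbers stand for an effect already at smaller amounts and higher numbers for an effect only at larger amounts of compound.
Compound 2 `Cc1ccc2c(=O)n([C@@H]3O[C@H](COP(=O)(O)OP(=O)(O)OP(=O)(O)O)[C@@H](O)[C@H]3O)ccc2c1` gives 35 nM in this assay.
Compound 3 `Cc1ccc2ccn([C@@H]3O[C@H](COP(=O)(O)OP(=O)(O)OP(=O)(O)O)[C@@H](O)[C@H]3O)c(=O)c2c1` gives 148 nM in this assay.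

Compound 3 has the highest number of the three, and its gaps to compound 1 and to compound 2 both lie beyond the scatter. Compound 4 `CSc1ccc2ccn([C@@H]3O[C@H](COP(=O)(O)OP(=O)(O)OP(=O)(O)O)[C@@H](O)[C@H]3O)c(=O)c2c1` differs from compound 3 by methylsulfanyl in place of methyl on an aromatic carbon, in words methylsulfanyl in place of methyl on an aromatic carbon. Among the measured compounds shown here, no measured pair shows this change, so no direction can be drawn from the series. The step from compound 3 to compound 4 in this assay is expected to stay within the scatter, a 1.3-fold lower number from compound 3 to compound 4 (0.13 log units; within the scatter). For compound 4 the estimate in this assay is 110 nM, in the range 35 nM to 350 nM.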

Compound 4, half-maximal effective concentration: 140 nM
Compound 4: the middle estimate sits 1.3-fold (0.10 log units) below what was measured; measured number inside the range.
By their numbers in this assay, from the lowest: compounds 2 and 1 (each within the scatter of the next); then compounds 4 and 3 (each within the scatter of the next).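

In this assay, methylsulfanyl in place of methyl on an aromatic carbon gives a 1.1-fold lower number from compound 3 to compound 4 (0.02 log units; within the scatter), which is within the scatter. At this place, meta to a fused ring and para to a fused ring, the added sulfur and hydrogen-bond acceptor therefore produce no readable difference. No available evidence bears on this result.

As far as these compounds go, whether an amine, a carboxylic acid or a longer chain such as ethylsulfanyl at this aromatic carbon would also stay level with methyl remains open. Also open, from the compounds shown here alone, is whether methylsulfanyl would read the same in place of the methyl of compound 2.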